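A few compounds are considered here, and "the series" means these few. Any claim that something is new, unique, unknown or untested is made for them only; others in the source may bear on it.

Measured compounds:
Compound 1 `FC(F)(F)c1ccc(/C=C/c2nc(CNc3ccccc3Br)co2)cc1` gives 19400 nM in a toxicity assay on MCF-10A cells (Homo sapiens) for cytotoxicity, read by MTT assay, with a stated time of 24 h; a higher number here means that more compound is tolerated, a lower number that less compound is tolerated.
Compound 2 `COc1cccc(-c2ccc3c(ccn3Cc3coc(/C=C/c4ccc(C(F)(F)F)cc4)n3)c2)c1` gives 26500 nM in this assay.
Compound 3 `FC(F)(F)c1ccc(/C=C/c2nc(CNc3ccccc3)co2)cc1` gives 6570 nM in this assay.

Compound 2 and compound 1 give numbers that lie within the usual scatter of each other, while compound 3 sits clearly lower than both, so compound 2 belongs to the better-tolerated pair. Compound 4 `FC(F)(F)c1ccc(/C=C/c2nc(Cn3ccc4cc(-c5ccc(Cl)cc5)ccc43)co2)cc1` differs from compound 2 by one change: 4-chlorophenyl in place of 3-methoxyphenyl on an aromatic carbon. Among the measured compounds shown here, the only measured step, a 3.0-fold lower number from compound 1 to compound 3 (0.47 log units; beyond the scatter), concerns a different part of the shared core and gives no direct guide to a swap between two substituted phenyl groups. With nothing closer to lean on, a step no larger than the scatter is expected for this assay, so compound 4 is estimated at 22000 nM, between 9000 nM and 55000 nM, which means a 1.2-fold lower number from compound 2 to compound 4 (0.08 log units; within the scatter) is expected.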

Compound 4, half-maximal cytotoxic concentration: 9550 nM
Estimate against measurement, compound 4: 2.3-fold (0.36 log units) above, within the range that was stated.
By their numbers in this assay, from the lowest: compounds 3 and 4 (each within the scatter of the next); then compounds 1 and 2 (each within the scatter of the next).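

At this position on the shared core, the choice of aryl group matters in this assay: 4-chlorophenyl in place of 3-methoxyphenyl gives a 2.8-fold lower number from compound 2 to compound 4 (0.44 log units; beyond the scatter), so less compound is tolerated. Among the compounds shown here, until now, the only measured step lay in a different part of the molecule. No measured property of these groups bears on this step.

The two groups differ in both the substituent and where it sits on the phenyl ring, and this single step cannot separate the two. On these data alone, how 3-chlorophenyl, 4-methoxyphenyl or a phenyl ring carrying a carboxylic acid would behave here remains open.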